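The source may hold more compounds than are shown below. What is called first, only, known or untested is meant among the compounds shown, and "the series" means these compounds.

Measured in an ADME assay on microsomes from liver (Mus musculus) for metabolic stability, read by LC-MS, with a stated time of 30 min, tested at 0.1 uM; on this read-out lower numbers stand for a less stable compound and higher numbers for a more stable compound: compound 1 `FC(F)(F)c1cccc(-c2nc3cnc(Nc4ccccn4)cc3[nH]2)c1` gives 47%; compound 2 `Fc1ccc(-c2nc3cnc(Nc4ccccn4)cc3[nH]2)cc1F` gives 7.5%; compound 3 `FC(F)(F)c1ccc(Nc2cc3[nH]c(-c4cccc(C(F)(F)F)c4)nc3cn2)nc1` gives 91%.

Compound 2 stands lowest of the three, its steps to compound 1 and compound 3 both beyond the scatter. Compound 3 differs from compound 1 by trifluoromethyl in place of hydrogen on an aromatic carbon, and that change made a number 44 percentage points higher from compound 1 to compound 3 (beyond the scatter). The cores of compound 1 and compound 2 differ in a way that is not broken down here. Compound 4 `Fc1ccc(-c2nc3cnc(Nc4cc(C(F)(F)F)ccn4)cc3[nH]2)cc1F` differs from compound 2 by trifluoromethyl in place of hydrogen on an aromatic carbon; the place is not the same, so this is the same kind of change, not the same change. Resting on a number 44 percentage points higher from compound 1 to compound 3 (beyond the scatter), compound 4 is expected to rise from compound 2 by a number 27.5 percentage points higher from compound 2 to compound 4 (beyond the scatter), with wide uncertainty. The estimate for compound 4 in this assay is 35%, between 10% and 65%.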

Compound 4, percent of the compound remaining in the Mus musculus assay: 78%
Beside the measured number, compound 4's estimate is 43 percentage points below it, and the stated range ends below it.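

In the Mus musculus assay compound 2 gives 7.5% and compound 4 gives 78%, and trifluoromethyl in place of hydrogen on an aromatic carbon gave a number 70.5 percentage points higher from compound 2 to compound 4 (beyond the scatter). This kind of change raised the number on both cores, but not by the same amount: the same change on two cores in the Mus musculus assay, a number 44 percentage points higher (beyond the scatter) from compound 1 to compound 3 and a number 70.5 percentage points higher (beyond the scatter) from compound 2 to compound 4, 26.5 percentage points apart, beyond the scatter of two such steps

The direction carried over and the size did not, and since the group sits at a different place in the two steps, these two pairs cannot separate the effect of the core from that of the place. In a physicochemical assay for solubility, using the shake flask method, measured as kinetic solubility, with a stated time of 20 h, at pH 2 (a higher number here means a more soluble compound, a lower number a less soluble compound), compound 2 gives 125000 nM. In the physicochemical assay compound 4 gives < 5000 nM, which is a limit of the assay and not a number. In the physicochemical assay the same step gave an at least 25-fold lower number from compound 2 to compound 4 (1.39 log units; beyond the scatter), a figure that rests on that limit for compound 4, not on a number.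

The compounds shown leave open how each core would respond to trifluoromethyl at the place it occupies on the other. They also leave open whether a nitrile, a methoxy group or an amine at these places would change the numbers in the same way.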